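Ethyl on the aromatic nitrogen of compound 1

A few compounds are considered here, and "the series" means these few. Any claim that something is new, unique, unknown or untested is made for them only; others in the source may bear on it.

- compound 1 `COc1cc(C(=O)c2ccc3[nH]ccc3c2)cc(OC)c1OC`: 104 nM
- compound 2 `COc1cc(C(=O)c2cccc3c2ccn3C)cc(OC)c1OC`: 22.1 nM

Both values come from a functional assay on KB cells (Homo sapiens) for inhibition, with a stated time of 72 h; a lower number here means a stronger inhibitor, a higher number a weaker inhibitor. Compound 1 stands highest of the two measured compounds, making it the weaker inhibitor, and the gap to compound 2 lies beyond the scatter. The next compound to be tested is compound 3 `CCn1ccc2cc(C(=O)c3cc(OC)c(OC)c(OC)c3)ccc21`. Its difference from compound 1 is ethyl in place of hydrogen on an aromatic nitrogen.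

No measured pair in the series differs at one place only, so the size of this change has not been shown directly. The two values alone do not settle its direction. The expectation therefore starts from compound 1 at 104 nM, with a slight fall at most and no step beyond the scatter expected. The expected step is a 1.2-fold lower number from compound 1 to compound 3 (0.06 log units; within the scatter). Compound 3 is estimated at 90 nM, with an expected range of 30 nM to 300 nM.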

Compound 3, half-maximal inhibitory concentration: 36 nM
Compound 3: the middle estimate sits 2.5-fold (0.40 log units) above what was measured, within the range that was stated.
By their numbers in this assay, from the lowest: compounds 2 and 3 (each within the scatter of the next); then compound 1.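

The aromatic nitrogen of the five-membered ring now has its first directly readable change: in this assay, ethyl in place of hydrogen gives a 2.9-fold lower number from compound 1 to compound 3 (0.46 log units; beyond the scatter) and so counts as a modest gain in inhibition, not a neutral swap. For the compounds shown here, this is the first pair that differs in one place only, and it shows that the hydrogen on this nitrogen is not required for inhibition in these cells and that the position accepts a chain of this size. Nothing measured on these compounds accounts for the gain.

Going by these compounds, whether the gain grows, holds or reverses with a longer chain such as propyl or butyl on this nitrogen remains open. The response to a chain ending in an amine or a carboxylic acid at the same place is also unknown.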